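A Chloro Swap on the Benzylsulfanyl Arm

The source may report more compounds than this note shows. Statements on the series, on what has been measured and on what is new or still open speak of the compounds shown alone.

In a functional assay on the whole organism (artery, strain albino) with Rattus norvegicus as the target, with a stated time of 900 min, at a dose of 10 mg/kg by the oral route (on this read-out lower numbers stand for less inhibition and higher numbers for more inhibition at the one dose given (going by the name of the read-out)), compound 2 `CC1=C(C(=O)Nc2ccc([N+](=O)[O-])cc2)C(c2cccc([N+](=O)[O-])c2)N=C(SCc2ccccc2)N1` gives 14.9%. That is the higher of the two numbers in hand; the nearest is compound 1 `CC1=C(C(=O)Nc2ccc([N+](=O)[O-])cc2)C(c2ccc(Br)cc2)N=C(SCc2ccccc2Cl)N1`, which in this assay gives 4.1%, a gap beyond the scatter. Compound 3 `CC1=C(C(=O)Nc2ccc([N+](=O)[O-])cc2)C(c2cccc([N+](=O)[O-])c2)N=C(SCc2ccccc2Cl)N1` has not yet been measured in this assay. It is reached from compound 2 by a single change: chloro in place of hydrogen on an aromatic carbon. Within the data shown here, no pair already measured differs by just this change, so the size of the step cannot be read off from the data. Among the measured compounds shown here, compound 1 carries the same chlorine but a different group on the core, and its reading shows only that a lower number is possible. The expected step in this assay is a number 2.9 percentage points lower from compound 2 to compound 3 (within the scatter), small and likely within the scatter. Compound 3 is estimated to give 12%, in a range from 2% to 28%.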

Compound 3, a percentage reported as inhibition, in the whole organism at one dose (the size of the read-out at that dose, not a potency): 7.2%
Estimate against measurement, compound 3: 4.8 percentage points above; low and high end bracket the measured number.
By their numbers in this assay, from the lowest: compounds 1, 3 and 2 (each within the scatter of the next, the first and the last beyond it).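

In this assay, the chloro change now has a direct reading: with the 3-nitrophenyl group held fixed, placing chloro on an aromatic carbon, ortho to a large group, gives a number 7.7 percentage points lower from compound 2 to compound 3 (within the scatter), so benzyl to 2-chlorobenzyl has no effect that can be told from the scatter. With the 2-chlorobenzyl group held fixed, the second single change, 3-nitrophenyl in place of 4-bromophenyl on a saturated ring carbon, gives a number 3.1 percentage points higher from compound 1 to compound 3 (within the scatter), and this step also cannot be told from the scatter. No data at hand bear on the reason for either step.

From the compounds shown here alone, it remains open whether a different group at this place, such as a methoxy group, an amine or a carboxylic acid, would give a step beyond the scatter. Going by these compounds, the effect of removing the chloro while the 4-bromophenyl group stays in place also remains open.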